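The compounds below may be only part of what the source reports. "The series", "measured", "known", "first", "only" and "open" are said of these compounds alone.

Compound 1 `COc1ccc(/C=C/c2cc(OC)cc(OC)c2/C=C/C(=O)c2cc3cc(OC)ccc3oc2=O)cc1` gives > 60000 nM in an assay on isolated protein for inhibition of Amine oxidase [flavin-containing] A (Homo sapiens), read by fluorescence, with a stated time of 15 min (a lower number here means a stronger inhibitor, a higher number a weaker inhibitor), a limit of the assay rather than a number.
Compound 2 `COc1ccc(/C=C/c2cc(OC)cc(OC)c2/C=C/C(=O)c2cc3cc(F)ccc3oc2=O)cc1` gives 44300 nM in this assay.
Compound 3 `COc1ccc(/C=C/c2cc(OC)cc(OC)c2/C=C/C(=O)c2cc3ccc(OC)cc3oc2=O)cc1` gives > 60000 nM in this assay, again a limit rather than a number.

Going by the values given here, all three share one core and differ only in the single group carried on its fused aromatic ring. Among the compounds with values here, compound 2 therefore holds the only real number among the three values shown; the other two values are limits. Within the data shown here, the single step that can be read between them is an at least 1.3-fold lower number from compound 1 to compound 2 (0.13 log units; that floor lies within the scatter), and its floor rests on (the limit of > 60000 nM in this assay, at which 2 of the 3 values shown sit), so it only says that compound 2 lies somewhere at or beyond that limit, not how far.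

Compound 4 `COc1ccc(/C=C/c2cc(OC)cc(OC)c2/C=C/C(=O)c2cc3cc(Cl)ccc3oc2=O)cc1` differs from compound 2 by chloro in place of fluoro on an aromatic carbon. Among the measured compounds shown here, no measured step exchanges one halogen for another; the only measured step exchanges a methoxy for a fluoro on an aromatic carbon of the same core, and even that step reaches only a floor within the scatter. On this slim basis the exchange of fluoro for chloro is expected to move the number by no more than the scatter, an expected 1.1-fold lower number from compound 2 to compound 4 (0.04 log units; within the scatter) in this assay. Compound 4 is thus estimated at 40000 nM, with a range from 15000 nM to 100000 nM.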

Compound 4, half-maximal inhibitory concentration: > 60000 nM
Compound 4 gave a limit, no number; the forecaster's own chance of this, stated with the estimate: 35%; middle value at least 1.5-fold (0.17 log units) away from the limit.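

With chloro in place of fluoro on this aromatic carbon, the readable number of compound 2 gives way to a limit of the assay in this assay, and the step is an at least 1.3-fold higher number from compound 2 to compound 4 (0.13 log units; that floor lies within the scatter). This is the first measured exchange of one halogen for another at this position, and its floor, like the earlier one, does not clear the scatter, so the one real number in the set is not yet shown to stand apart from the compounds around it. Chloro and methoxy cannot be compared here either, since the step between compound 1 and compound 4 cannot be read: the limit of > 60000 nM in this assay, at which 3 of the 4 values shown sit.

Going by these compounds, how far past the limit compound 1 and compound 4 really lie stays open, and with it whether fluoro differs from chloro by more than the scatter. Also open, on these data alone, is whether another group on this aromatic carbon, such as an amine, a carboxylic acid or a nitrile, would bring the number clearly lower than that of compound 2.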